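This account rests on a few compounds, and the source may have more. Where it says the series, first, only, none or still open, it means among the compounds named here.

Compound 1 `COc1ccc(/C=C/c2cc(OC)cc(OC)c2/C=C/C(=O)c2cc3ccccc3oc2=O)cc1` gives 9170 nM in an assay on isolated protein for inhibition of Amine oxidase [flavin-containing] B (Homo sapiens), read by fluorescence, with a stated time of 15 min; a lower number here means a stronger inhibitor, a higher number a weaker inhibitor. Compound 3 `COc1ccc(/C=C/c2cc(OC)cc(OC)c2/C=C/C(=O)c2cc3cc(C)ccc3oc2=O)cc1`, carrying methyl in place of hydrogen on an aromatic carbon, gives 5090 nM in this assay. That step is a 1.8-fold lower number from compound 1 to compound 3 (0.26 log units; within the scatter). For compound 2 `COc1ccc(/C=C/c2cc(OC)cc(OC)c2/C=C/C(=O)c2cc3cc(Br)cc(OC)c3oc2=O)cc1` this assay reports only a limit, > 60000 nM, namely (the limit of > 60000 nM in this assay, at which 1 of the 3 values shown sits). Compound 4 `COc1ccc(/C=C/c2cc(OC)cc(OC)c2/C=C/C(=O)c2cc3cc(Br)ccc3oc2=O)cc1` differs from compound 2 by hydrogen in place of methoxy on an aromatic carbon. Going by the values given here, no measured step removes a methoxy group, and the only measured change on this ring, from hydrogen to methyl, stayed within the scatter. Compound 4 is therefore expected to land near compound 1, at about 8000 nM, between 2500 nM and 30000 nM. The expected step from the limit of compound 2 is an at least 7.5-fold lower number from compound 2 to compound 4 (0.87 log units; beyond the scatter).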

Compound 4, half-maximal inhibitory concentration: > 60000 nM
Compound 4: no number, only a limit; the forecaster's own chance of this, stated with the estimate: 15%; middle value at least 7.5-fold (0.87 log units) away from the limit.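

With bromo in place of hydrogen on the aromatic carbon there is an at least 6.5-fold higher number from compound 1 to compound 4 (0.81 log units; beyond the scatter), and with bromo in place of methyl there is an at least 11-fold higher number from compound 3 to compound 4 (1.07 log units; beyond the scatter), so in this assay this position accepts methyl but not bromo. Compound 4 gives only a limit, > 60000 nM, so the loss seen in compound 2 persists without its methoxy group. The step between compound 2 and compound 4 cannot be read, as both stand at a limit: the limit of > 60000 nM in this assay, at which 2 of the 4 values shown sit.

On these data alone, whether fluoro or chloro at the bromo position would keep a measurable value stays open. As far as these compounds go, how far compound 2 and compound 4 lie beyond the limit also stays open.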